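Replacing the trifluorobenzyl group with a phenylethyl group

The source may report more compounds than this note shows. Statements on the series, on what has been measured and on what is new or still open speak of the compounds shown alone.

Measured so far:
- Compound 1, `COc1ccc2[nH]c3c(c2c1)CCNC31CCN(Cc2ccc(Cl)cc2Cl)CC1`: 1800 nM
- Compound 2, `COc1ccc2[nH]c3c(c2c1)CCNC31CCN(Cc2cc(F)c(F)cc2F)CC1`: 600 nM

Both compounds share one core and differ only in the group attached to the amine nitrogen in a ring. In an assay on FRT cells for positive allosteric modulation of Cystic fibrosis transmembrane conductance regulator variant N1303K (Homo sapiens), in the presence of a further agent that is not named here (on this read-out lower numbers stand for an effect already at smaller amounts and higher numbers for an effect only at larger amounts of compound), compound 1 gives 1800 nM, and compound 2 gives 600 nM. Going by the values given here, the one step measured, a 3.0-fold lower number from compound 1 to compound 2 (0.48 log units; beyond the scatter), shows that swapping the halogen pattern on that aromatic ring changes the number by a modest amount. Compound 2 therefore stands at the lower of the two numbers.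

Compound 3, `COc1ccc2[nH]c3c(c2c1)CCNC31CCN(C(C)c2ccccc2)CC1`, carries the change (1-phenylethyl in place of 2,4,5-trifluorobenzyl on an amine nitrogen in a ring). This change is of a different kind from the measured step: all three fluorine atoms leave and a methyl branch appears on the carbon joined to the nitrogen. Among the compounds with values here, no measured pair shows the effect of removing halogens or of adding that branch, so the single step from compound 1 to compound 2 gives only a rough sense of how sensitive this position is, and no direction.

Compound 3 is expected to give 1500 nM in this assay, within a range from 500 nM to 5000 nM, which would mean a step of a 2.5-fold higher number from compound 2 to compound 3 (0.40 log units; beyond the scatter).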

Compound 3, half-maximal effective concentration: 20000 nM
For compound 3 the middle estimate is 13-fold (1.12 log units) below the measured one; measured number above the stated range.
By their numbers in this assay, from the lowest: compound 2; then compound 1; then compound 3.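

In this assay this position proves able to move the number much further than the swap of halogen patterns had shown: the change to 1-phenylethyl brings a 33-fold higher number from compound 2 to compound 3 (1.52 log units; beyond the scatter) and, measured against the 2,4-dichlorobenzyl group, it brings an 11-fold higher number from compound 1 to compound 3 (1.05 log units; beyond the scatter) in the same direction. Among these three compounds, both halogen-bearing benzyl groups therefore give lower numbers than the 1-phenylethyl group, so a direction for this kind of change now exists where the earlier pair offered none. Nothing available here explains why the number rises so far.

The compounds shown leave open whether the rise goes with the loss of the halogens or with the methyl branch on the carbon joined to the nitrogen, since both differences arrive together in compound 3. A plain benzyl group, with neither halogens nor the branch, would pull these two differences apart, and a pyridylmethyl group would test whether this position accepts a nitrogen within the aromatic ring.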